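This account rests on a few compounds, and the source may have more. Where it says the series, first, only, none or still open, it means among the compounds named here.

Measured so far in an assay on isolated protein for inhibition of G protein-coupled receptor kinase 6 (Homo sapiens), read by scintillation counting, radiometric assay and 33P incorporation, with a stated time of 80 min, in the presence of a further agent that is not named here; on this read-out lower numbers stand for stronger inhibition and higher numbers for weaker inhibition:
- compound 1, `CCc1cc(Nc2nc(N[C@@H](C)c3ccc(F)cn3)nc3cccc(F)c23)n[nH]1`: 29 nM
- compound 2, `CCc1cc(Nc2nc(N[C@@H](C)c3ncc(F)cn3)nc3cccc(F)c23)n[nH]1`: 230 nM

Compound 2 gives the highest of the two numbers in this assay; its nearest neighbour is compound 1, and the step of a 7.9-fold higher number from compound 1 to compound 2 (0.90 log units; beyond the scatter) is beyond the scatter. That step, 5-fluoropyrimidin-2-yl in place of 5-fluoropyridin-2-yl on a saturated chain carbon bound to a nitrogen on an aromatic ring and a saturated chain carbon, is the only one measured.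

Compound 3, `CCc1cc(Nc2nc(N[C@@H](C)c3ccc(F)cc3)nc3cccc(F)c23)n[nH]1`, differs from compound 2 by 4-fluorophenyl in place of 5-fluoropyrimidin-2-yl on a saturated chain carbon bound to a nitrogen on an aromatic ring and a saturated chain carbon. Among the compounds with values here, the one measured step bears on it only loosely, as it goes the other way on the same ring and walks further, beyond compound 1. A move back toward or past compound 1 is expected, though with wide uncertainty. The expected step is a 5.8-fold lower number from compound 2 to compound 3 (0.76 log units; beyond the scatter). For compound 3 the estimate in this assay is 40 nM, range 10 nM to 160 nM.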

Compound 3, half-maximal inhibitory concentration: 41 nM
Beside the measured number, compound 3's estimate is 1.0-fold (0.01 log units) below it, within the range that was stated.
By their numbers in this assay, from the lowest: compounds 1 and 3 (each within the scatter of the next); then compound 2.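

In this assay, 4-fluorophenyl in place of 5-fluoropyrimidin-2-yl gives a 5.6-fold lower number from compound 2 to compound 3 (0.75 log units; beyond the scatter), while 4-fluorophenyl in place of 5-fluoropyridin-2-yl gives a 1.4-fold higher number from compound 1 to compound 3 (0.15 log units; within the scatter). At this position, on the saturated chain carbon, a ring of carbon only and 5-fluoropyridin-2-yl therefore cannot be told apart, and 5-fluoropyrimidin-2-yl alone of the three stands apart, with the higher number. Nothing measured in this set accounts for that difference.

The compounds shown all carry a fluorinated six-membered aromatic ring here, so it remains open how a saturated ring such as cyclohexyl, a longer chain or an amine would fare at this position. Also open, on these data alone, is whether the fluorine itself matters, a question that plain phenyl or 4-chlorophenyl would address.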